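Swapping the aryl group on the hydrazone carbon

The source may report more compounds than this note shows. Statements on the series, on what has been measured and on what is new or still open speak of the compounds shown alone.

Within the data shown here, compound 2 `CN(C)CCn1cnnc1-c1cc(Oc2ccc(NC(=O)N/N=C/c3cccc(Br)c3)cc2F)ccn1` gives the lowest of the two numbers so far: in a functional assay on MKN-45 cells (Homo sapiens) for cytotoxicity, read by MTT assay, with a stated time of 72 h (on this read-out higher numbers stand for weaker inhibition and lower numbers for stronger inhibition), compound 2 gives 450 nM, while compound 1 `COc1ccc(/C=N/NC(=O)Nc2ccc(Oc3ccnc(-c4nncn4CCN(C)C)c3)c(F)c2)c(OC)c1` gives 1680 nM. Among the measured compounds shown here, the one step known, a 3.7-fold lower number from compound 1 to compound 2 (0.57 log units; beyond the scatter), bears directly on compound 3 `COc1ccc(/C=N/NC(=O)Nc2ccc(Oc3ccnc(-c4nncn4CCN(C)C)c3)c(F)c2)cc1O`, which differs from compound 2 by 3-hydroxy-4-methoxyphenyl in place of 3-bromophenyl on a carbon with a double bond to nitrogen. An oxygen-bearing phenyl thus returns, resembling compound 1, so a higher number is expected, about a 2.7-fold higher number from compound 2 to compound 3 (0.43 log units; beyond the scatter). Compound 3 is estimated at 1200 nM, within a range from 450 nM to 3200 nM.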

Compound 3, half-maximal inhibitory concentration: 2510 nM
The estimate for compound 3 lay 2.1-fold (0.32 log units) below the measured number; the measured number falls inside the stated range.
By their numbers in this assay, from the lowest: compound 2; then compounds 1 and 3 (each within the scatter of the next).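

In this assay the step of a 5.6-fold higher number from compound 2 to compound 3 (0.75 log units; beyond the scatter) shows that a second oxygen-bearing phenyl group on this carbon also gives a higher number than 3-bromophenyl. The step of a 1.5-fold higher number from compound 1 to compound 3 (0.17 log units; within the scatter) separates 3-hydroxy-4-methoxyphenyl from 2,4-dimethoxyphenyl by no more than the scatter, so these two substitution patterns cannot be ranked here. No available evidence accounts for the difference from 3-bromophenyl. Still open, on these data alone, is whether 3-chlorophenyl or unsubstituted phenyl would match 3-bromophenyl, and whether a bromine at another ring position would give a similar number.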